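From Ethynyl to Ethenyl: a Small Step Expected

The source may report more compounds than this note shows. Statements on the series, on what has been measured and on what is new or still open speak of the compounds shown alone.

Compound 1 `CNC(=O)C#Cc1ccc(NC(=O)Nc2ccc(Cl)c(C(F)(F)F)c2)cc1`: 23300 nM
Compound 2 `CC(NC(=O)c1cccc(-c2ccc(NC(=O)Nc3ccc(Cl)c(C(F)(F)F)c3)cc2)c1)c1ccccc1`: 5670 nM

Of the two measured compounds, compound 1 has the highest number in a functional assay on HepG2 cells (Homo sapiens) for inhibition, read by MTT assay, with a stated time of 120 h (a higher number here means a weaker inhibitor, a lower number a stronger inhibitor), giving 23300 nM. Compound 2 gives 5670 nM, a lower number, and the gap between the two lies beyond the scatter.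

Compound 3 `CNC(=O)/C=C/c1ccc(NC(=O)Nc2ccc(Cl)c(C(F)(F)F)c2)cc1` differs from compound 1 in one place: 2-(methylcarbamoyl)ethenyl in place of 2-(methylcarbamoyl)ethynyl on an aromatic carbon. Nothing measured here tracks this kind of exchange, so the step is expected to be small, leaning towards a slightly lower number but not clearly beyond the scatter; the step from compound 1 to compound 3 is estimated as a 1.6-fold lower number from compound 1 to compound 3 (0.19 log units; within the scatter). Compound 3 is expected to give about 15000 nM, within a range of 5000 nM to 45000 nM.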

Compound 3, half-maximal inhibitory concentration: 20400 nM
Compound 3: middle estimate off by 1.4-fold (0.13 log units), on the low side; the measured number falls inside the stated range.
By their numbers in this assay, from the lowest: compound 2; then compounds 3 and 1 (each within the scatter of the next).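

In this assay the exchange of 2-(methylcarbamoyl)ethynyl for 2-(methylcarbamoyl)ethenyl, on an aromatic carbon para to a large group, gives a 1.1-fold lower number from compound 1 to compound 3 (0.06 log units; within the scatter) and so shows that this read-out does not separate the two groups at this position. The triple bond can therefore give way to a double bond here with no change beyond the scatter. No measured evidence accounts for this result.

Still open, from the compounds shown here alone, is how far this position tolerates other groups, such as a carboxylic acid or an amine at the end of the chain. A longer chain in place of the methylcarbamoyl end is equally untested by these compounds.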